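Swapping an Aminophenyl for a Dichlorophenyl

The source may report more compounds than this note shows. Statements on the series, on what has been measured and on what is new or still open speak of the compounds shown alone.

Measured so far:
compound 1, `COc1cc(-c2cc(/C=C/C(=O)c3ccc(N)cc3)[nH]n2)cc(OC)c1OC`, gives 5420 nM
compound 2, `COc1ccc(-c2cc(/C=C/C(=O)c3ccc(OC)c(OC)c3)[nH]n2)cc1`, gives 5380 nM

Both compounds were tested in a functional assay on SF-539 cells (Homo sapiens) for inhibition, read by sulforhodamine B assay, with a stated time of 48 h; a higher number here means that more compound is tolerated, a lower number that less compound is tolerated. The values of compound 1 and compound 2 are separated by a gap that lies within the scatter, so the two cannot be told apart on these measurements. Among the compounds with values here, no pair of compounds differing in a single place has been measured against each other, so there is no known step to lean on.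

Compound 3, `COc1cc(-c2cc(/C=C/C(=O)c3ccc(Cl)c(Cl)c3)[nH]n2)cc(OC)c1OC`, has not yet been measured. It differs from compound 1 as follows: 3,4-dichlorophenyl in place of 4-aminophenyl on a carbonyl carbon. Within the data shown here, no measured step tells how such a change plays out on this core in this assay, so any expectation must be loose. The swap is expected to move the number by at most a modest amount, with no clear direction, and a result within the scatter of compound 1 is as likely as not.

For compound 3 in this assay the estimate is 5000 nM, with a range from 1500 nM to 16000 nM, which would mean an expected step of a 1.1-fold lower number from compound 1 to compound 3 (0.04 log units; within the scatter).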

Compound 3, concentration lethal to 50% of the cells: 57800 nM
Compound 3: the middle estimate sits 12-fold (1.06 log units) below what was measured; the whole stated range lies below it.
By their numbers in this assay, from the lowest: compounds 2 and 1 (each within the scatter of the next); then compound 3.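

Putting 3,4-dichlorophenyl in place of 4-aminophenyl on a carbonyl carbon gives an 11-fold higher number from compound 1 to compound 3 (1.03 log units; beyond the scatter) in this assay, a large step well beyond the scatter. Within the data shown here, this is the first comparison here of two compounds that differ in one place, and it shows that the group at this position is not a neutral bystander: changing it alone strongly alters how much compound the cells tolerate, and this swap moves the number upward. The swap removes the nitrogen, with its counted hydrogen-bond donor and acceptor, and brings in two chlorine atoms, but no measurement here explains why the number moves.

The step therefore cannot be divided between losing the amino group and gaining the chlorines, and a plain phenyl or a phenyl carrying a single chlorine would be needed to separate those two parts of the change. Going by these compounds, it also remains open whether a step of this size would hold on a different core, such as that of compound 2, which differs from compound 1 in more than one place.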